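From Methyl to Phenyl on a Shared Core

The source may report more compounds than this note shows. Statements on the series, on what has been measured and on what is new or still open speak of the compounds shown alone.

For the measured compounds named here, in a functional assay on Hs-578T cells (Homo sapiens) for inhibition, read by sulforhodamine B assay, with a stated time of 48 h (a higher number here means a weaker inhibitor of growth, a lower number a stronger inhibitor of growth), compound 1 `Cc1nnc(-c2nn(-c3ccccc3)c(-c3ccccc3)c2C#N)c2cn(-c3ccccc3)nc12` gives 1390 nM, the lower of the two numbers measured so far. Compound 2 `N#Cc1c(-c2nnc(-c3nn(-c4ccccc4)c(-c4ccccc4)c3C#N)c3nn(-c4ccc(Cl)cc4)cc23)nn(-c2ccccc2)c1-c1ccccc1` gives 9720 nM, and that gap lies beyond the usual scatter of repeated measurements. Compound 3 `N#Cc1c(-c2nnc(-c3ccccc3)c3nn(-c4ccccc4)cc23)nn(-c2ccccc2)c1-c1ccccc1` keeps the core of compound 1 and changes one group: phenyl in place of methyl on an aromatic carbon. In words, a phenyl stands in place of a methyl on an aromatic carbon. Going by the values given here, no measured pair isolates this change, so the evidence is thin. The only larger molecule tested, compound 2 at 9720 nM, differs in several places and offers just a weak hint towards a higher number. The expected move is a 2.2-fold higher number from compound 1 to compound 3 (0.33 log units; beyond the scatter), a moderate weakening that may not stand far beyond the scatter. For compound 3 the estimated value is 3000 nM, with an expected range from 1000 nM to 9000 nM.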

Compound 3, concentration for 50% growth inhibition: 31800 nM
Estimate against measurement, compound 3: 11-fold (1.03 log units) below; the whole stated range lies below it.
By their numbers in this assay, from the lowest: compound 1; then compound 2; then compound 3.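

In this assay, for the compounds shown here, putting phenyl in place of methyl on this aromatic carbon gives a 23-fold higher number from compound 1 to compound 3 (1.36 log units; beyond the scatter), a large step and the first measured pair that isolates this single change. The position is therefore not indifferent to the group it carries: on this core, the methyl goes with much stronger growth inhibition than the phenyl, and one swap at this site is enough to move the number this far. No measurement on these compounds accounts for the size of the step.

Going by these compounds alone, with only two groups compared at this position, a single pair cannot show how the number depends on the group placed there. An ethyl chain, an amine or a methoxy group on the same carbon could show whether the number stays near that of compound 1 or climbs towards that of compound 3.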